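A few compounds are considered here, and "the series" means these few. Any claim that something is new, unique, unknown or untested is made for them only; others in the source may bear on it.

Of the compounds shown here, two built on the same core have been measured so far. Compound 1 `CNc1ncnc2c(CNc3cc(NC(=O)c4cccc(C(F)(F)F)c4)ccc3C)cccc12` carries a 3-(trifluoromethyl)phenyl on the carbonyl carbon of the amide, and in a functional assay on A375P cells (Homo sapiens) for cytotoxicity, read by MTT assay, with a stated time of 24 h (a lower number here means a stronger inhibitor, a higher number a weaker inhibitor), compound 1 gives 433 nM. Compound 2 `CNc1ncnc2c(CNc3cc(NC(=O)c4cc(C)on4)ccc3C)cccc12` carries instead a 5-methyl-1,2-oxazol-3-yl at that carbonyl carbon, and in this assay compound 2 gives 1200 nM. Among the compounds with values here, that swap produced a 2.8-fold higher number from compound 1 to compound 2 (0.44 log units; beyond the scatter), so compound 2 stands with the higher of the two numbers, its only neighbour being compound 1.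

Compound 3 `CNc1ncnc2c(CNc3cc(NC(=O)c4cscn4)ccc3C)cccc12` is the next member. It differs from compound 2 in one place: 1,3-thiazol-4-yl in place of 5-methyl-1,2-oxazol-3-yl on a carbonyl carbon. Within the data shown here, the only measured step, from compound 1 to compound 2, exchanged a six-membered ring for a five-membered ring with two hetero atoms and gave a modest rise; the move from compound 2 to compound 3 keeps a five-membered ring with two hetero atoms, so there is no measured step that directly tracks it. The step from compound 2 to compound 3 in this assay is therefore expected to be small, likely within the scatter, namely a 1.1-fold lower number from compound 2 to compound 3 (0.04 log units; within the scatter). For compound 3 the estimated value in this assay is 1100 nM, with a range from 450 nM to 2700 nM.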

Compound 3, half-maximal inhibitory concentration: 1900 nM
For compound 3 the middle estimate is 1.7-fold (0.24 log units) below the measured one, and the stated range covers the measured number.
By their numbers in this assay, from the lowest: compound 1; then compounds 2 and 3 (each within the scatter of the next).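

In this assay, putting the 1,3-thiazol-4-yl on the carbonyl carbon in place of the 5-methyl-1,2-oxazol-3-yl gives a 1.6-fold higher number from compound 2 to compound 3 (0.20 log units; within the scatter), so these two five-membered aromatic rings with 2 hetero atoms cannot be told apart here, although they differ in one ring atom, sulfur for oxygen, and in the methyl group. The comparison with the six-membered ring gives a 4.4-fold higher number from compound 1 to compound 3 (0.64 log units; beyond the scatter), which means that both five-membered rings shown now stand apart from the 3-(trifluoromethyl)phenyl, and none of the three compounds goes against this. Nothing measured here offers a reason for either step.

The compounds shown leave open whether the lower number of compound 1 goes with the phenyl ring itself or with its trifluoromethyl group, and a plain phenyl on the same carbonyl carbon is the comparison that would separate the two. Also open is how a pyridine ring, a piperidine or a ring carrying a carboxylic acid would read at this position in this assay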